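The compounds below may be only part of what the source reports. "The series", "measured", "known", "first", "only" and "open" are said of these compounds alone.

Of the compounds shown here, three built on a shared core have been measured in an ADME assay on microsomes from liver (Homo sapiens) for metabolic stability, read by LC-MS, using NADPH, with a stated time of 10 min, tested at 0.1 uM; on this read-out lower numbers stand for slow clearance and higher numbers for fast clearance. Compound 1, `COc1ccccc1N1C(=O)CSC1c1cc(F)cc(C(=O)NCCCCc2ccccc2)c1`, gives 2080 mL.min-1.g-1 in this assay. Compound 2, `C#Cc1cc(C(=O)NCCCCc2ccccc2)cc(C2SCC(=O)N2c2ccccc2OC)c1`, gives 1730 mL.min-1.g-1 in this assay. These two differ in one place only, namely fluoro in place of ethynyl on an aromatic carbon and that change made a 1.2-fold higher number from compound 2 to compound 1 (0.08 log units; within the scatter). Compound 3, `C#Cc1cccc(N2C(=O)CSC2c2cccc(C(=O)NCCCCc3ccccc3)c2)c1`, gives 751 mL.min-1.g-1 in this assay, the lowest of the three numbers, and its steps to compound 2 and to compound 1 both lie beyond the scatter. Compound 3 and compound 2 differ in more than one place, and the difference between the two cores is not broken down here.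

Compound 4, `O=C(NCCCCc1ccccc1)c1cccc(C2SCC(=O)N2c2cccc(F)c2)c1`, has not yet been measured. It differs from compound 3 by fluoro in place of ethynyl on an aromatic carbon which is the same kind of change as that from compound 2 to compound 1, though not the same: in compound 2 the ethynyl sits meta to two large groups, in compound 3 it sits meta to a large group. Resting on the earlier pair, which gave a 1.2-fold higher number from compound 2 to compound 1 (0.08 log units; within the scatter), the expected step for compound 4 is a 1.1-fold higher number from compound 3 to compound 4 (0.05 log units; within the scatter). In this assay compound 4 is therefore estimated at 850 mL.min-1.g-1, with a likely range from 420 mL.min-1.g-1 to 1700 mL.min-1.g-1.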

Compound 4, intrinsic clearance in microsomes in the Homo sapiens assay: 1840 mL.min-1.g-1
The estimate for compound 4 lay 2.2-fold (0.34 log units) below the measured number, and the stated range ends below it.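

In the Homo sapiens assay, fluoro in place of ethynyl made a 2.5-fold higher number from compound 3 to compound 4 (0.39 log units; beyond the scatter). In a physicochemical assay for solubility, read by turbidimetry, measured as kinetic solubility, at pH 6.8 (on this read-out higher numbers stand for higher solubility and lower numbers for lower solubility), compound 3 gives 10000 nM and compound 4 gives 10000 nM, and the same change gave no change at the digits printed from compound 3 to compound 4 (within the scatter). Set beside the earlier pair on the core of compound 2, the step in the Homo sapiens assay cannot be told apart from the one seen there: the same change on two cores in the Homo sapiens assay, a 1.2-fold higher number (0.08 log units; within the scatter) from compound 2 to compound 1 and a 2.5-fold higher number (0.39 log units; beyond the scatter) from compound 3 to compound 4, 2.0-fold (0.31 log units) apart, within the scatter of two such steps These two pairs are compatible with a single shared step for this change, but they do not establish one, and they do not show that the core alters the step either; only the step on the core of compound 3 lies beyond the scatter by itself.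

The compounds shown leave open whether fluoro in place of ethynyl would give a step of similar size on any further core, as two pairs are too few to settle how well it carries over. They also leave open how other groups on that aromatic carbon, such as a nitrile, a chlorine atom, an amine or a carboxylic acid, would compare with fluoro and ethynyl in the Homo sapiens assay.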